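A few compounds are considered here, and "the series" means these few. Any claim that something is new, unique, unknown or untested is made for them only; others in the source may bear on it.

Compound 2 `Cc1ccc(-n2cc(-c3ccccc3NS(=O)(=O)c3c[nH]c(=O)[nH]c3=O)nn2)cc1` gives 32400 nM in an ADME assay on GES1 cells (Homo sapiens) for cytotoxicity, read by MTT assay, with a stated time of 24 h (on this read-out higher numbers stand for lower toxicity in this test and lower numbers for higher toxicity in this test), the higher of the two numbers recorded so far. Its nearest neighbour is compound 1 `Cc1ccccc1-n1cc(-c2ccccc2NS(=O)(=O)c2c[nH]c(=O)[nH]c2=O)nn1`, which gives 19900 nM in this assay; the step of a 1.6-fold higher number from compound 1 to compound 2 (0.21 log units; within the scatter) separates them, and it stays within the scatter of the method.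

Compound 3 `O=c1[nH]cc(S(=O)(=O)Nc2ccccc2-c2cn(-c3ccccc3F)nn2)c(=O)[nH]1` has not yet been measured. It differs from compound 2 by the change (2-fluorophenyl in place of 4-methylphenyl on an aromatic nitrogen), a swap of one aryl group for another on the same aromatic nitrogen of the shared core. Among the compounds with values here, the only measured step that bears on this position is the one from compound 1 to compound 2, where one methylphenyl group replaced another and the number moved by a 1.6-fold higher number from compound 1 to compound 2 (0.21 log units; within the scatter), a shift no larger than the scatter. On that single precedent, a replacement of the aryl group on this nitrogen is not expected to move the result beyond the scatter in either direction.

Compound 3 is therefore estimated at 26000 nM, with a range from 11000 nM to 62000 nM, which amounts to an expected step of a 1.2-fold lower number from compound 2 to compound 3 (0.10 log units; within the scatter).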

Compound 3, half-maximal cytotoxic concentration: > 100000 nM
Compound 3 gave a limit, no number (the forecaster's own chance of this, stated with the estimate: 10%); at least 3.8-fold (0.58 log units) between middle value and limit.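

The aryl group on this aromatic nitrogen turns out to matter in this assay, which the earlier pair could not show, since the swap of 2-methylphenyl for 4-methylphenyl stayed within the scatter, with a 1.6-fold higher number from compound 1 to compound 2 (0.21 log units; within the scatter). The 2-fluorophenyl group gives an at least 3.0-fold higher number from compound 2 to compound 3 (0.48 log units; beyond the scatter), and fluoro in place of methyl on an aromatic carbon gives an at least 5.0-fold higher number from compound 1 to compound 3 (0.70 log units; beyond the scatter), so both changes leading to compound 3 go beyond the scatter, towards lower toxicity in this test. On these data alone, compound 3 gives > 100000 nM, which is a limit and not a number, so the full size of both steps stays unknown because the result sits at the top of the range reported: the limit of > 100000 nM in this assay, at which 1 of the 3 values shown sits.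

With only one fluorinated compound, the compounds shown leave open whether this shift belongs to fluoro as such or to fluoro in this particular arrangement, which a 4-fluorophenyl group would help to separate. They also leave open how a chloro group, a methoxy group or an amine on the same phenyl ring would read in this assay.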